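The compounds below may be only part of what the source reports. "The series", "measured", "known", "first", "only" and "open" are said of these compounds alone.

Measured in an ADME assay on MRC5 cells (Homo sapiens) for inhibition, with a stated time of 72 h; a lower number here means that less compound is needed, a higher number that more compound is needed for the effect:
- Compound 1 `CO[C@H]1CC[C@H](NC(=O)c2n[nH]cc2NC(=O)c2cc(Cl)cc(Cl)c2)CC1`: 13000 nM
- Compound 2 `CO[C@H]1CC[C@H](NC(=O)c2n[nH]cc2NC(=O)C2CCC(F)(F)CC2)CC1`: > 50000 nM (a limit)

Compound 2 gives no number in this assay, only the limit > 50000 nM. This reading is the limit of > 50000 nM in this assay, at which 1 of the 2 values shown sits. The next compound to be measured is compound 3 `CO[C@H]1CC[C@H](NC(=O)c2n[nH]cc2NC(=O)c2cc3ccccc3o2)CC1`, in which 1-benzofuran-2-yl takes the place of 4,4-difluorocyclohexyl on a carbonyl carbon: 1-benzofuran-2-yl in place of 4,4-difluorocyclohexyl on a carbonyl carbon.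

Within the data shown here, only one measured step bears on this change: an at least 3.8-fold higher number from compound 1 to compound 2 (0.58 log units; beyond the scatter). In that step, an aromatic group on the same carbonyl carbon gave way to 4,4-difluorocyclohexyl. Compound 3 restores an aromatic group there, although 1-benzofuran-2-yl is not the 3,5-dichlorophenyl of compound 1. A move towards a lower number in this assay is therefore expected, of modest size, and the evidence is thin because it rests on an at least 3.8-fold higher number from compound 1 to compound 2 (0.58 log units; beyond the scatter) alone. A reading at the limit remains possible for compound 3. The expected change is an at least 2.2-fold lower number from compound 2 to compound 3 (0.35 log units; beyond the scatter). For compound 3 the estimated value is 22000 nM, with an expected range from 8000 nM to 50000 nM.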

Compound 3, half-maximal effective concentration: 800 nM
The estimate for compound 3 lay 28-fold (1.44 log units) above the measured number, outside the stated range (below it).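

The group on this carbonyl carbon matters far more in this assay than the first pair could show, with an at least 62-fold lower number from compound 2 to compound 3 (1.79 log units; beyond the scatter). The full size of this step cannot be read, because compound 2 gives only a limit: the limit of > 50000 nM in this assay, at which 1 of the 3 values shown sits. The result also shows that the two aromatic groups at this place are not interchangeable, since 1-benzofuran-2-yl in place of 3,5-dichlorophenyl gives a 16-fold lower number from compound 1 to compound 3 (1.21 log units; beyond the scatter), so an aromatic group as such does not fix the number and the identity of that group counts as well.

These three compounds cannot separate the contributions of the oxygen and the second ring of 1-benzofuran-2-yl, a question that a plain phenyl, a furan-2-yl or a 1-benzothiophene-2-yl at the same carbonyl carbon would bear on directly. It also remains open whether the same order among these groups would hold if the methoxy on the cyclohexane ring, which is shared by all three compounds, gave way to an amine or a carboxylic acid.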